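The source may hold more compounds than are shown below. What is called first, only, known or untested is meant among the compounds shown, and "the series" means these compounds.

In an assay on Caudate-putamen for displacement of a labelled ligand from sodium-dependent dopamine transporter (Rattus norvegicus), read by scintillation counting (on this read-out lower numbers stand for stronger inhibition and higher numbers for weaker inhibition), compound 3 `CN(C)CCCC1(c2ccc(F)cc2)OCc2c(/C=C/c3ccccc3)cccc21` gives 1140 nM; compound 1 `CN(C)CCCC1(c2ccc(F)cc2)OCc2cc(-c3ccccc3)ccc21` gives 1800 nM, and the gap between them lies within the scatter. Compound 2 `COc1cccc(-c2ccc3c(c2)COC3(CCCN(C)C)c2ccc(F)cc2)c1` has "not determined" (no result reported) in this assay, so no number stands for it. Compound 4 `CN(C)CCCC1(c2ccc(F)cc2)OCc2c(-c3cccc(F)c3)cccc21` differs from compound 3 by 3-fluorophenyl in place of 2-phenylethenyl on an aromatic carbon. Among the compounds with values here, no step between measured compounds isolates this change, and compound 1 carries its phenyl at a different place, so the direction is open. The step from compound 3 to compound 4 in this assay is expected to be small, a 1.3-fold higher number from compound 3 to compound 4 (0.12 log units; within the scatter), not clearly beyond the scatter. Compound 4 is estimated at 1500 nM, with a range from 500 nM to 4500 nM.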

Compound 4, inhibition constant: 490 nM
For compound 4 the middle estimate is 3.1-fold (0.49 log units) above the measured one, and the stated range ends above it.
By their numbers in this assay, from the lowest: compound 4; then compounds 3 and 1 (each within the scatter of the next).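

Within the data shown here, on this aromatic carbon, this assay gives the first step that isolates a single change: 3-fluorophenyl in place of 2-phenylethenyl brings a 2.3-fold lower number from compound 3 to compound 4 (0.37 log units; beyond the scatter). The earlier compounds shown here held no such pair, so this shows that the group at this place can move the number beyond the scatter. Nothing measured here explains the step. On these data alone, what an unsubstituted phenyl or an amine would give on this carbon remains open, so the share of the fluorine cannot be separated from that of the lost double bond.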